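Swapping the Aryl on Compound 2: Toward Compound 3

The source may report more compounds than this note shows. Statements on the series, on what has been measured and on what is new or still open speak of the compounds shown alone.

Compound 1 `COc1cc2ncnc(NCc3cccc(NC(=O)Nc4ccc(C)cc4)c3)c2cc1OC`: in a functional assay on HepG2 cells (Homo sapiens) for antiproliferative activity, read by MTT assay (a higher number here means a weaker inhibitor, a lower number a stronger inhibitor), compound 1 reaches only the limit > 50000 nM.
Compound 2 `COc1cc2ncnc(NCc3cccc(NC(=O)Nc4ccccc4Cl)c3)c2cc1OC`: in this assay compound 2 gives 25500 nM.

Within the data shown here, compound 2 holds the only actual number in this assay; the other value is a limit (the limit of > 50000 nM in this assay, at which 1 of the 2 values shown sits). Among the measured compounds shown here, the single step measured, an at least 1.9-fold lower number from compound 1 to compound 2 (0.29 log units; that floor lies within the scatter), has a floor that lies within the usual scatter, so it is not known whether the change at this position moved the number at all. Compound 3 `COc1cc2ncnc(NCc3cccc(NC(=O)Nc4ccc([N+](=O)[O-])cc4)c3)c2cc1OC` differs from compound 2 by 4-nitrophenyl in place of 2-chlorophenyl on an amide-type nitrogen. That same amide-type nitrogen is the place the measured step touched, but that step gives no clear size or direction to carry over. Compound 3 is therefore expected to sit close to compound 2, with a step of a 1.2-fold higher number from compound 2 to compound 3 (0.07 log units; within the scatter) in this assay. The estimate for compound 3 in this assay is 30000 nM, in a range from 10000 nM to 100000 nM.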

Compound 3, half-maximal inhibitory concentration: 18800 nM
For compound 3 the middle estimate is 1.6-fold (0.20 log units) above the measured one, within the range that was stated.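

Among these compounds, the methyl-to-nitro change on the aromatic carbon gives the first step at this position that clears the scatter, an at least 2.6-fold lower number from compound 1 to compound 3 (0.42 log units; beyond the scatter), so the group on this ring can matter in this assay. That step is only a floor, as compound 1 holds a limit and not a number: the limit of > 50000 nM in this assay, at which 1 of the 3 values shown sits. By contrast, a 1.4-fold lower number from compound 2 to compound 3 (0.13 log units; within the scatter) does not separate 4-nitrophenyl from 2-chlorophenyl on the amide-type nitrogen, so the two groups cannot be ranked.

On these data alone, how large the true gap from compound 1 is remains open, as does whether the nitro group itself is needed or whether a chlorine at the same ring carbon would serve equally. As far as these compounds go, it is also open how an amine or a carboxylic acid at that carbon would read in this assay.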